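This account rests on a few compounds, and the source may have more. Where it says the series, first, only, none or still open, it means among the compounds named here.

Working notes on a small set of thiourea-bridged dihydropyrimidine esters bearing a furan ring, all tested in an assay on membranes from CHO cells for displacement of a labelled ligand from adenosine receptor A1 (Homo sapiens), read by scintillation counting, with a stated time of 60 min, tested at 1 uM; a higher number here means more inhibition at the concentration tested (going by the name of the read-out), a lower number less inhibition.

Compound 1 `CCCOC(=O)C1=C(C)NC(=S)NC1c1ccco1` gives 1%. Compound 2 `CC1=C(C(=O)OCC(C)C)C(c2ccco2)NC(=S)N1` gives 7% in this assay. Compound 3 `CCCOC(=O)C1=C(C)NC(=S)NC1c1ccoc1` gives 4% in this assay. All three numbers sit close to one another; the step of a number 6 percentage points higher from compound 1 to compound 2 (within the scatter) and the step of a number 3 percentage points higher from compound 1 to compound 3 (within the scatter) both fall inside the usual scatter, so no ordering among compounds 1, 2 and 3 can be read from them.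

Compound 4 `CC1=C(C(=O)OCC(C)C)C(c2ccoc2)NC(=S)N1` is not yet measured. Compound 4 stands to compound 3 as compound 2 stands to compound 1: the change methyl in place of hydrogen on a saturated chain carbon bound to two saturated chain carbons is the same as methyl in place of hydrogen on a saturated chain carbon bound to two saturated chain carbons, with the place described in the same words, and the change occurs twice among the compounds shown. Going by the values given here, the cores of compound 1 and compound 3 differ by furan-3-yl in place of furan-2-yl on a saturated ring carbon, a change that in the measured pair gave only the step of a number 3 percentage points higher from compound 1 to compound 3 (within the scatter).

For compound 4 in this assay the expected step is a number 4 percentage points higher from compound 3 to compound 4 (within the scatter), set beside the measured step of a number 6 percentage points higher from compound 1 to compound 2 (within the scatter) from the same change on the other core. This expectation rests on that single measured step and on the low starting value of compound 3, which gives 4% in this assay. Compound 4 is therefore estimated at 8%, with a likely range from 0% to 20%.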

Compound 4, a percentage reported as inhibition, at one concentration (the size of the read-out at that concentration, not a potency): 12%
Compound 4: the middle estimate sits 4 percentage points below what was measured, within the range that was stated.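

In this assay, methyl in place of hydrogen on a saturated chain carbon bound to two saturated chain carbons gives a number 8 percentage points higher from compound 3 to compound 4 (within the scatter), and set beside the step from the same change on the other core it shows no difference between the two cores: the same change on two cores in this assay, a number 6 percentage points higher (within the scatter) from compound 1 to compound 2 and a number 8 percentage points higher (within the scatter) from compound 3 to compound 4, 2 percentage points apart, within the scatter of two such steps. Furan-3-yl in place of furan-2-yl on a saturated ring carbon gives a number 5 percentage points higher from compound 2 to compound 4 (within the scatter), and this change also reads alike on both cores: the same change on two cores in this assay, a number 3 percentage points higher (within the scatter) from compound 1 to compound 3 and a number 5 percentage points higher (within the scatter) from compound 2 to compound 4, 2 percentage points apart, within the scatter of two such steps. Going by these compounds alone, each of these steps lies within the scatter, so the agreement shows only that neither change gives any sign of depending on the core, not that either change has a real effect in this assay or that its size carries over from one core to another.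

The compounds shown leave open whether a longer chain or a benzyl group on the ester oxygen, or a phenyl or pyridine ring in place of the furan, would give a step beyond the scatter. They also leave open whether such a step would carry from one core to another, and, with a read-out at one concentration only, they give no potency for any of the compounds.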